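Amine swap on the alkoxy chain: compound 3 to compound 4

The source may hold more compounds than are shown below. What is called first, only, known or untested is meant among the compounds shown, and "the series" means these compounds.

Measured compounds in a functional assay on A549 cells (Homo sapiens) for cytotoxicity, read by MTT assay, with a stated time of 72 h; on this read-out lower numbers stand for stronger inhibition and higher numbers for weaker inhibition:
- compound 1 `COc1c(OCCCCN2CCN(C)CC2)cc(O)c2c(=O)cc(-c3ccc(C)cc3)oc12`: 3810 nM
- compound 2 `COc1c(OCCCCN2CCN(C)CC2)cc(O)c2c(=O)cc(-c3ccc(F)cc3Br)oc12`: 2980 nM
- compound 3 `CN(C)CCCOc1c(OCc2ccccc2)cc(O)c2c(=O)cc(-c3ccccc3)oc12`: 2910 nM

Compound 3 holds the lowest of the three numbers in this assay, but its gap to compound 2 and to compound 1 is within the scatter, so no order among the three can be read from these values. Going by the values given here, the only measured step, a 1.3-fold lower number from compound 1 to compound 2 (0.11 log units; within the scatter), concerns the aryl group on the shared core and stays within the scatter.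

Compound 4 `O=c1cc(-c2ccccc2)oc2c(OCCCCN3CCCC3)c(OCc3ccccc3)cc(O)c12` differs from compound 3 by (pyrrolidin-1-yl)methyl in place of dimethylamino on a saturated chain carbon, three bonds along the chain from an oxygen on an aromatic ring. Among the compounds with values here, no measured step touches this part of the molecule, so nothing in the three values speaks for a shift in either direction. The expectation is therefore no step beyond the scatter, a 1.0-fold lower number from compound 3 to compound 4 (0.00 log units; within the scatter), in this assay. Compound 4 is estimated at 2900 nM, with a range from 1200 nM to 7000 nM.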

Compound 4, half-maximal inhibitory concentration: 1100 nM
For compound 4 the middle estimate is 2.6-fold (0.42 log units) above the measured one; the whole stated range lies above it.
By their numbers in this assay, from the lowest: compound 4; then compounds 3, 2 and 1 (each within the scatter of the next).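

In this assay, going by these compounds alone, the alkoxy chain end is the first place where a single change goes beyond the scatter, with a 2.6-fold lower number from compound 3 to compound 4 (0.42 log units; beyond the scatter) in this one step. The change reads in full as 3-(dimethylamino)propyl to 4-(pyrrolidin-1-yl)butyl, so a longer chain and a ring on the amine enter together, and this step cannot divide the shift between them. No measurement at hand offers an explanation for the shift.

Still open, from the compounds shown here alone, is which part of the change carries the step: a 3-(pyrrolidin-1-yl)propyl or a 4-(dimethylamino)butyl group on the otherwise unchanged structure of compound 3 would separate the two. Also open, going by these compounds, is whether another ring amine at the chain end, such as piperidine or morpholine, would give a similar number.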